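Replacing the benzodioxinyl of compound 3 with methoxyphenyl

The compounds below may be only part of what the source reports. "The series", "measured", "known", "first", "only" and "open" are said of these compounds alone.

Compound 3 `O=C(O)c1cccc(-c2cn(-c3ccc(-c4ccc5c(c4)OCCO5)cc3)nn2)c1` gives 668 ug/mL in a physicochemical assay for solubility, measured as thermodynamic solubility (on this read-out higher numbers stand for higher solubility and lower numbers for lower solubility), the highest of the three numbers measured. Compound 2 `COc1cc(OC)cc(-c2ccc(-n3cc(-c4cccc(C(=O)O)c4)nn3)cc2)c1` gives 18.7 ug/mL, and compound 1 `COc1ccc(OC)c(-c2ccc(NC(=O)c3ccncc3F)cc2)c1`, which has a different core, gives 0.28 ug/mL. Among the measured compounds shown here, the one single-point step measured is a 36-fold higher number from compound 2 to compound 3 (1.55 log units; beyond the scatter), a large gain brought by the 2,3-dihydro-1,4-benzodioxin-6-yl group.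

Compound 4 `COc1cccc(-c2ccc(-n3cc(-c4cccc(C(=O)O)c4)nn3)cc2)c1` reverses that direction: 3-methoxyphenyl in place of 2,3-dihydro-1,4-benzodioxin-6-yl on an aromatic carbon. The 3-methoxyphenyl that enters is close to the 3,5-dimethoxyphenyl of compound 2, differing only by one methoxy, so the step measured from compound 2 to compound 3 bears directly on it. A large drop in this assay is therefore expected, of roughly the size seen in that step, though the single methoxy leaves room for compound 4 to land somewhat apart from compound 2 in either direction. The expected step is a 17-fold lower number from compound 3 to compound 4 (1.22 log units; beyond the scatter). Compound 4 is estimated at 40 ug/mL in this assay, within a range from 10 ug/mL to 200 ug/mL.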

Compound 4, solubility: 856 ug/mL
The estimate for compound 4 lay 21-fold (1.33 log units) below the measured number; measured number above the stated range.
By their numbers in this assay, from the lowest: compound 1; then compound 2; then compounds 3 and 4 (each within the scatter of the next).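

In this assay the exchange of 2,3-dihydro-1,4-benzodioxin-6-yl for 3-methoxyphenyl gives a 1.3-fold higher number from compound 3 to compound 4 (0.11 log units; within the scatter) and so does not separate these two groups at this position, para to a large group. Among the compounds shown here, the large step lies instead in the one methoxy that separates compound 2 from compound 4: hydrogen in place of methoxy gives a 46-fold higher number from compound 2 to compound 4 (1.66 log units; beyond the scatter) and shows that the low number of compound 2 goes with the extra methoxy, not with the methoxyphenyl group as such. Nothing measured here bears on why one methoxy makes so large a step.

Still open, as far as these compounds go, is how an amine or a fluorine in place of that methoxy would read in this assay. Also open, from the compounds shown here alone, is how the numbers would move if a primary amide stood in place of the carboxylic acid shared by compound 2, compound 3 and compound 4.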